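The source may hold more compounds than are shown below. What is called first, only, known or untested is meant among the compounds shown, and "the series" means these compounds.

Of the compounds shown here, three of one family have so far been measured in a functional assay for agonist activity at Free fatty acid receptor 1 (Homo sapiens); a lower number here means that less compound is needed, a higher number that more compound is needed for the effect. Compound 1 `O=C(O)CCc1ccc(NCc2ccc(Cl)cc2)cc1` gives 1000 nM in this assay. Compound 2 `O=C(O)CCc1cccc(NCc2ccc(-c3ccccc3)cc2)c1` gives 501 nM. Compound 3 `O=C(O)CCc1ccc(NCc2ccc(C(F)(F)F)cc2)cc1` gives 2000 nM, the highest of the three numbers. For the measured compounds named here, its nearest neighbour is compound 1, and the only single-point comparison among the measured compounds is the one between them: a 2.0-fold higher number from compound 1 to compound 3 (0.30 log units; within the scatter). Compound 2 gives a clearly lower number than compound 3, but the two differ in more than one place, so their values alone cannot be tied to a single group.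

Compound 4 `CN(C)Cc1ccc(CNc2ccc(CCC(=O)O)cc2)cc1` is the next compound in line. It differs from compound 3 at the same aromatic carbon that was changed between compound 1 and compound 3: (dimethylamino)methyl in place of trifluoromethyl on an aromatic carbon. Going by the values given here, the one measured step that bears on this carbon, a 2.0-fold higher number from compound 1 to compound 3 (0.30 log units; within the scatter), stayed within the scatter, and no measured compound carries a (dimethylamino)methyl group anywhere. On that basis the step expected in this assay, a 1.3-fold lower number from compound 3 to compound 4 (0.12 log units; within the scatter), is one that does not rise beyond the scatter. Compound 4 is therefore estimated at 1500 nM, with a range from 500 nM to 4500 nM.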

Compound 4, half-maximal effective concentration: < 31700 nM
Compound 4 ended at the assay's limit; the forecaster's own chance of this, stated with the estimate: 10%; the middle value lies beyond the limit too.
By their numbers in this assay, from the lowest: compounds 2, 1 and 3 (each within the scatter of the next, the first and the last beyond it).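

In this assay compound 4 gives < 31700 nM, which is a limit of the assay and not a number. Neither the step from compound 1 to compound 4 nor the step from compound 3 to compound 4 can be read. The compounds shown leave open how (dimethylamino)methyl on this aromatic carbon compares with chloro or trifluoromethyl in this assay.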